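A few compounds are considered here, and "the series" means these few. Any claim that something is new, unique, unknown or untested is made for them only; others in the source may bear on it.

In a functional assay on A-431 cells (Homo sapiens) for antiproliferative activity, read by MTT assay (on this read-out higher numbers stand for weaker inhibition and lower numbers for stronger inhibition), three compounds sharing one core have been measured. Compound 1 `N#Cc1c(F)c(Cl)c(C(C(=O)c2ccccc2)=C2NCCN2)c(C#N)c1F` gives 87.1 ug/mL, compound 2 `N#Cc1c(F)c(F)c(C(C(=O)c2ccccc2)=C2NCCN2)c(C#N)c1F` gives 5.5 ug/mL, and compound 3 `N#Cc1c(F)c(C#N)c(C(C(=O)c2ccccc2)=C2NCCN2)c(F)c1Nc1ccccc1` gives 5.3 ug/mL. Compound 2 thus stands level with compound 3, and both lie far from compound 1, at the stronger end of the numbers shown.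

The compound still awaiting measurement, compound 4 `Cc1ccc(C(=O)C(=C2NCCN2)c2c(F)c(F)c(C#N)c(F)c2C#N)cc1`, differs from compound 2 only in its benzoyl group, which becomes (4-methylphenyl)carbonyl. The difference is methyl in place of hydrogen on an aromatic carbon, para to a large group.

Two measured steps are available, and neither touches this group. Fluoro in place of chloro gave a 16-fold lower number from compound 1 to compound 2 (1.20 log units; beyond the scatter), a large step, whereas anilino in place of fluoro gave a 1.0-fold lower number from compound 2 to compound 3 (0.02 log units; within the scatter), which lies within the scatter. Neither therefore measures the methyl change directly, and the data hold no other substitution on the benzoyl group. A single methyl here is expected to produce no step beyond the scatter, but the range is kept wide because a 16-fold lower number from compound 1 to compound 2 (1.20 log units; beyond the scatter) shows that one substitution can move this series strongly.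

The estimated change is a 1.1-fold higher number from compound 2 to compound 4 (0.04 log units; within the scatter). Compound 4 is expected at 6 ug/mL, with an estimated range from 2.5 ug/mL to 15 ug/mL.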

Compound 4, half-maximal inhibitory concentration: 0.5 ug/mL
For compound 4 the middle estimate is 12-fold (1.08 log units) above the measured one; measured number outside the range, below it.
By their numbers in this assay, from the lowest: compound 4; then compounds 3 and 2 (each within the scatter of the next); then compound 1.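

In this assay, the benzoyl group turns out to be a place where this series responds strongly: methyl in place of hydrogen on an aromatic carbon, para to a large group, gives an 11-fold lower number from compound 2 to compound 4 (1.04 log units; beyond the scatter). Within the data shown here, the earlier steps left this group untouched, so the only large step known until now was a 16-fold lower number from compound 1 to compound 2 (1.20 log units; beyond the scatter), and compound 4 shows that a second, separate part of the molecule can also produce a large step. Nothing among the data offered here accounts for the effect of this single added methyl, and its cause stays unexplained.

The compounds shown give only one substitution on the benzoyl group, so they leave open whether a larger ethyl chain, a methoxy group or an amine at the same place would move the number in the same direction, or by a similar amount, and whether the methyl would act alike at another carbon of that ring. They also leave open whether the same methyl would have a comparable effect on compound 3, where an anilino group replaces a fluoro.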